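Adding a Second Chloro Group: From Compound 3 to Compound 4

A few compounds are considered here, and "the series" means these few. Any claim that something is new, unique, unknown or untested is made for them only; others in the source may bear on it.

Measured so far in a functional assay on the whole organism with Mus musculus as the target; a lower number here means that less compound is needed, a higher number that more compound is needed for the effect:
Compound 1, `OC1CCN(c2ccc(-c3ccccc3Cl)nn2)CC1`, gives 38 mg/kg.
Compound 2, `OC1CCN(c2ccc(-c3ccc(Cl)cc3Cl)nn2)CC1`, gives 8.5 mg/kg.
Compound 3, `O=C1CCN(c2ccc(-c3ccccc3Cl)nn2)CC1`, gives 35 mg/kg.

Compound 2 differs from compound 1 by one change, (chloro in place of hydrogen on an aromatic carbon), and that change gave a 4.5-fold lower number from compound 1 to compound 2 (0.65 log units; beyond the scatter). Compound 3 carries a different core; the difference between the two cores is not broken down here. Its value in this assay lies within the usual scatter of the value of compound 1, so the two are not told apart by this measurement.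

Compound 4, `O=C1CCN(c2ccc(-c3ccc(Cl)cc3Cl)nn2)CC1`, is not yet measured. It differs from compound 3 by chloro in place of hydrogen on an aromatic carbon, which is the same change as that from compound 1 to compound 2, made on the same place of the ring. Because that change gave a 4.5-fold lower number from compound 1 to compound 2 (0.65 log units; beyond the scatter), a step of similar size is expected from compound 3 to compound 4, namely a 4.4-fold lower number from compound 3 to compound 4 (0.64 log units; beyond the scatter). Compound 4 is therefore estimated to give about 8 mg/kg in this assay, most likely between 4 mg/kg and 16 mg/kg.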

Compound 4, dose for half-maximal effect: 7.3 mg/kg
Estimate against measurement, compound 4: 1.1-fold (0.04 log units) above, and the stated range covers the measured number.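

Adding the chloro group gave a 4.8-fold lower number from compound 3 to compound 4 (0.68 log units; beyond the scatter) in this assay, and the change kept practically its size when carried from the core with 4-hydroxypiperidin-1-yl to the core with 4-oxopiperidin-1-yl: the same change on two cores in this assay, a 4.5-fold lower number (0.65 log units; beyond the scatter) from compound 1 to compound 2 and a 4.8-fold lower number (0.68 log units; beyond the scatter) from compound 3 to compound 4, 1.1-fold (0.03 log units) apart, within the scatter of two such steps

With the chloro group in place, exchanging these two groups gave a 1.2-fold lower number from compound 2 to compound 4 (0.07 log units; within the scatter), so this measurement does not tell the two compounds apart. This shows that the step held on these two closely related cores in this assay, but it does not show that the step would hold on any other core, and it does not explain how the chloro group lowers the number.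

The compounds shown leave open whether another group at that place on the ring, such as fluoro, methyl or methoxy, would give a step of similar size. They also leave open whether a group carrying an amine or a carboxylic acid in place of 4-oxopiperidin-1-yl would change the number.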